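The source may report more compounds than this note shows. Statements on the series, on what has been measured and on what is new or still open speak of the compounds shown alone.

Working notes on the series

The series shares one core, carried through compound 1 `Clc1ccc(Cn2nnc3c(Br)cccc32)cn1`, compound 2 `CCCCn1nnc2c(Br)cccc21`, compound 3 `Clc1cccc2c1nnn2CC1CC1` and the as yet unmeasured compound 4 `COc1cccc2c1nnn2CC1CC1`. In an ADME assay on microsomes from liver (Homo sapiens) for metabolic stability, tested at 2.5 uM (a higher number here means faster removal of the compound, a lower number slower removal), compound 1 gives "not determined" (no result reported), so no number is available for it. In this assay compound 2 gives 9.5 mL/min/g, and compound 3 gives 4.2 mL/min/g. Compound 3 therefore stands at the lowest of the two numbers that exist; its nearest neighbour is compound 2, whose number is higher by an amount that is beyond the usual scatter of repeated measurements.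

The move from compound 3 to compound 4 is a single change: methoxy in place of chloro on an aromatic carbon. For the measured compounds named here, no pair of measured compounds shows this exact change, so there is no measured step to lean on. The expectation is that the number for compound 4 comes out somewhat higher than that of compound 3, by a step of about a 1.7-fold higher number from compound 3 to compound 4 (0.22 log units; within the scatter), an amount that could still sit within the scatter of a repeat. On that basis compound 4 is estimated at 7 mL/min/g in this assay, with a plausible range from 3 mL/min/g to 16 mL/min/g.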

Compound 4, intrinsic clearance in a liver preparation (reported as CLH), per the amount of preparation that the assay uses: 1.8 mL/min/g
Compound 4: middle estimate off by 3.9-fold (0.59 log units), on the high side, outside the stated range (below it).
By their numbers in this assay, from the lowest: compound 4; then compound 3; then compound 2.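

In this assay, for the compounds shown here, the single change of methoxy in place of chloro on an aromatic carbon gives a 2.3-fold lower number from compound 3 to compound 4 (0.37 log units; beyond the scatter), the first step that isolates this position, which is ortho to a fused ring and meta to a fused ring. The earlier compounds shown here could not show this, as compound 2 and compound 3 differ in more than one place and compound 1 has no number; the step now shows that, with the rest of compound 3 held constant, the number falls on exchanging chloro for methoxy, a group with one more heavy atom and a hydrogen-bond acceptor. No measured information available here bears on the origin of this difference.

As far as these compounds go, this is one step on one background, so it remains open whether the same exchange gives a similar step on the core of compound 2, where a butyl group and bromo take the place of the groups in compound 3. Also open, from the compounds shown here alone, is how this aromatic carbon responds to other groups, such as ethoxy, a nitrile or an amine.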